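The source may report more compounds than this note shows. Statements on the series, on what has been measured and on what is new or still open speak of the compounds shown alone.

Measured compounds:
compound 1 `Nc1nc(N2CCN(C(=O)COc3ccc(Cl)cc3)CC2)c2ccsc2n1`, 330 nM
compound 2 `Nc1nc(N2CCN(C(=O)COc3ccc(F)cc3)CC2)c2ccsc2n1`, 66 nM

Within the data shown here, in a functional assay on cells (Lymphocyte) (a higher number here means a weaker inhibitor, a lower number a stronger inhibitor), compound 2 gives 66 nM, the lowest of the two numbers so far; the single known step, a 5.0-fold lower number from compound 1 to compound 2 (0.70 log units; beyond the scatter), separates it from compound 1. Compound 3 `Cc1cccc(OCC(=O)N2CCN(c3nc(N)nc4sccc34)CC2)c1` is not yet measured and differs from compound 2 by 3-methylphenyl in place of 4-fluorophenyl on an oxygen on a saturated carbon. Among the measured compounds shown here, no measured step covers this change: the only step known is fluoro in place of chloro on an aromatic carbon, which does not speak to a 3-methylphenyl group. That step does show the ring substituent moves this assay noticeably, so a number back toward compound 1 is plausible. Compound 3 is expected at 150 nM (range 50 nM to 500 nM), an expected step of a 2.3-fold higher number from compound 2 to compound 3 (0.36 log units; beyond the scatter).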

Compound 3, half-maximal inhibitory concentration: 210 nM
Compound 3: middle estimate off by 1.4-fold (0.15 log units), on the low side; the measured number falls inside the stated range.
By their numbers in this assay, from the lowest: compound 2; then compounds 3 and 1 (each within the scatter of the next).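

In this assay, 3-methylphenyl in place of 4-fluorophenyl on the oxygen gives a 3.2-fold higher number from compound 2 to compound 3 (0.50 log units; beyond the scatter). Set against 4-chlorophenyl, the same group gives a 1.6-fold lower number from compound 1 to compound 3 (0.20 log units; within the scatter), so these two groups cannot be told apart here, while 4-fluorophenyl stays alone at the low end of the three compounds. Nothing available explains this difference. Still open, as far as these compounds go, is how a nitrile, a methoxy group or an amine on the phenyl ring would read, and how a longer chain in place of the saturated carbon would read.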